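Oral bioavailability of a sulfonamide series: from compound 3 to compound 4

The compounds below may be only part of what the source reports. "The series", "measured", "known", "first", "only" and "open" are said of these compounds alone.

Of the compounds shown here, three of one shared core have been measured in an ADME assay on the whole organism (strain CD) for pharmacokinetics, with Rattus norvegicus as the target, at a dose of 1 mg/kg by the oral route; on this read-out lower numbers stand for lower oral bioavailability and higher numbers for higher oral bioavailability. Compound 1 `CC(=O)NCc1cccc(Cn2nc(NS(=O)(=O)c3ccc(Cl)s3)c3c(O)cccc32)c1` gives 12% in this assay. Compound 2 `CC(=O)NCc1cccc(Cn2nc(NS(=O)(=O)c3ccc(Cl)s3)c3c(C(C)O)cccc32)c1` gives 35% in this assay. Compound 3 `CN[C@H](C)C(=O)NCc1cccc(Cn2nc(NS(=O)(=O)c3ccc(Cl)s3)c3c(OC)cccc32)c1` gives 19% in this assay, which places it second highest of the three numbers: its nearest neighbour is compound 1, whose value lies within the scatter of compound 3, and its furthest is compound 2, whose value lies beyond the scatter above compound 3. Among the compounds with values here, the one measured step, a number 23 percentage points higher from compound 1 to compound 2 (beyond the scatter), concerns a change on the shared core rather than on the side chain.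

Compound 4 `COc1cccc2c1c(NS(=O)(=O)c1ccc(Cl)s1)nn2Cc1cccc(CNC(=O)C(C)(C)N)c1` is not yet measured. It differs from compound 3 by 1-amino-1-methylethyl in place of 1-(methylamino)ethyl on a carbonyl carbon. Within the data shown here, no measured step touches this part of the molecule, so nothing in the data speaks for a change in either direction; the group that leaves and the group that enters are of the same size and carry the same count of donors and acceptors.

Compound 4 is therefore expected to show no change at the digits printed from compound 3 to compound 4 (within the scatter) in this assay, a step not beyond the scatter. The estimate for compound 4 is 19%, with a range from 8% to 35%.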

Compound 4, oral bioavailability: 29%
Compound 4: the middle estimate sits 10 percentage points below what was measured; the range from low to high includes it.
By their numbers in this assay, from the lowest: compounds 1, 3, 4 and 2 (each within the scatter of the next, the first and the last beyond it).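

Within the data shown here, this is the first step that touches the side chain rather than the shared core: in this assay the exchange of 1-(methylamino)ethyl for 1-amino-1-methylethyl on a carbonyl carbon gives a number 10 percentage points higher from compound 3 to compound 4 (within the scatter) and thus does not separate the two compounds. The two groups have the same heavy atoms and the same counts of donors and acceptors, and the entering group gives up the defined stereocentre, so this pair shows that rearranging these atoms and losing that stereocentre together leave oral bioavailability within the scatter at this position. No measurement of any underlying property accompanies this result, so the data offer no explanation for the values of this pair.

As far as these compounds go, since only these two closely related groups are compared here, it remains open whether a dimethylamino group, a carboxylic acid or a longer chain at this carbonyl carbon would move the read-out beyond the scatter. From the compounds shown here alone, it is also open how 1-amino-1-methylethyl would behave on a core carrying 1-hydroxyethyl in place of the methoxy group of compound 4.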